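Adding one methoxy group to compound 3

This account rests on a few compounds, and the source may have more. Where it says the series, first, only, none or still open, it means among the compounds named here.

Values so far in a functional assay on HCT-116 cells (Homo sapiens) for cytotoxicity, read by sulforhodamine B assay, with a stated time of 48 h; on this read-out higher numbers stand for weaker inhibition and lower numbers for stronger inhibition
compound 1 `COc1cc(/C=C/C(=O)/C=C/c2cccc3ccccc23)ccc1OCc1cn(CCCOc2cc(=O)oc3ccccc23)nn1` gives 10400 nM
compound 2 `COc1cc(/C=C/C(=O)/C=C/c2cc(OC)c(OC)c(OC)c2)ccc1OCc1cn(CCOc2cc(=O)oc3ccccc23)nn1` gives 2210 nM
compound 3 `COc1ccc(/C=C/C(=O)/C=C/c2ccc(OCc3cn(CCCOc4cc(=O)oc5ccccc45)nn3)c(OC)c2)cc1OC` gives 11000 nM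

Compound 3 sits with compound 1 at the high, weakly inhibiting end of these numbers, and compound 2 gives a clearly lower one. Compound 4 `COc1cc(/C=C/C(=O)/C=C/c2cc(OC)c(OC)c(OC)c2)ccc1OCc1cn(CCCOc2cc(=O)oc3ccccc23)nn1` differs from compound 3 in one place: methoxy in place of hydrogen on an aromatic carbon. This is methoxy in place of hydrogen on an aromatic carbon, turning 3,4-dimethoxyphenyl into 3,4,5-trimethoxyphenyl. Among the compounds with values here, one measured step touches this end of the molecule: a 1.1-fold higher number from compound 1 to compound 3 (0.02 log units; within the scatter), where naphthalen-1-yl gave way to 3,4-dimethoxyphenyl. Apart from its chain, compound 4 matches compound 2, which gives 2210 nM. A modest move towards a lower number is therefore expected in this assay, perhaps none beyond the scatter. The estimated change is a 1.8-fold lower number from compound 3 to compound 4 (0.26 log units; within the scatter). Compound 4 is expected near 6000 nM, within a range of 2500 nM to 13000 nM.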

Compound 4, half-maximal inhibitory concentration: 8650 nM
Compound 4: middle estimate off by 1.4-fold (0.16 log units), on the low side, within the range that was stated.
By their numbers in this assay, from the lowest: compound 2; then compounds 4, 1 and 3 (each within the scatter of the next).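

In this assay, the added methoxy that turns 3,4-dimethoxyphenyl into 3,4,5-trimethoxyphenyl gives a 1.3-fold lower number from compound 3 to compound 4 (0.10 log units; within the scatter) and so leaves the number unchanged in practice. Replacing naphthalen-1-yl with 3,4,5-trimethoxyphenyl gives a 1.2-fold lower number from compound 1 to compound 4 (0.08 log units; within the scatter) and likewise makes no clear difference, so all three end groups read alike on the longer-numbered compounds 1, 3 and 4. No measurement here explains this result. From the compounds shown here alone, it remains open whether an amine or a carboxylic acid on this aromatic carbon would shift the number beyond the scatter. Also open, going by these compounds, is whether compound 2 at 2210 nM stands apart through its chain alone.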